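The source may hold more compounds than are shown below. What is called first, only, known or untested is meant among the compounds shown, and "the series" means these compounds.

Measured in a functional assay on HEK293 cells for positive allosteric modulation of metabotropic glutamate receptor 5 (Homo sapiens), read by calcium flux; on this read-out higher numbers stand for larger maximal responses and lower numbers for smaller maximal responses:
compound 1 `O=C(C1CC1)N1CCCn2nc(COc3ccccc3)cc21` gives 61%
compound 2 `CC(=O)N1CCCn2nc(COc3cccc(F)c3)cc21` gives 58%
compound 3 `CC(=O)N1CCCn2nc(COc3ccc(F)cc3)cc21` gives 56%

Compound 3 holds the smallest of the three numbers, but compound 2 stands within the scatter of it and so does compound 1, so the three values cannot be told apart in this assay. Among the compounds with values here, the only single-point step among the measured compounds, a number 2 percentage points lower from compound 2 to compound 3 (within the scatter), exchanges 3-fluorophenyl for 4-fluorophenyl on an oxygen on a saturated carbon and stays within the scatter.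

Compound 4 `CC(=O)N1CCCn2nc(COc3ccncc3)cc21` has not yet been measured. It differs from compound 3 as follows: pyridin-4-yl in place of 4-fluorophenyl on an oxygen on a saturated carbon. Within the data shown here, no measured step exchanges the six-membered aromatic ring of carbon only for a six-membered aromatic ring with 1 hetero atom, so nothing in hand bears directly on this change; the fluorine shift in the one measured step is a different kind of alteration and only shows that the phenyl part tolerates small edits without movement beyond the scatter.

Compound 4 is therefore expected to land near the present values, with the estimate 50% in a range from 30% to 70%. Among the measured compounds shown here, the expected step is a number 6 percentage points lower from compound 3 to compound 4 (within the scatter), with the uncertainty deliberately wide since the ring exchange has no precedent in the measured set.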

Compound 4, largest response reached (reported as percent of maximum), in percent of the reference or control that the assay uses: < 15%
Compound 4 ended at the assay's limit; the forecaster's own chance of this, stated with the estimate: 5%; middle value at least 35 percentage points from the limit.
By their numbers in this assay, from the lowest: compounds 3, 2 and 1 (each within the scatter of the next). At a limit, below all of these: compound 4.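

In this assay, the fluorine shift had suggested that the aromatic ring on an oxygen on a saturated carbon tolerates small edits, but replacing that carbon-only ring with a ring holding one hetero atom gives a number at least 41 percentage points lower from compound 3 to compound 4 (beyond the scatter). The same exchange starting from the 3-fluorophenyl compound gives a number at least 43 percentage points lower from compound 2 to compound 4 (beyond the scatter), so this place in the series is sensitive to the identity of the ring, not only to where a fluorine sits. The value of compound 4 is a limit of the assay and not a number: the limit of < 15% in this assay, at which 1 of the 4 values shown sits.

On these data alone, whether the drop belongs to the ring nitrogen as such or to its place in the ring remains open, and pyridin-3-yl or pyridin-2-yl on the same oxygen would separate the two. Also open, as far as these compounds go, is whether pyridin-4-yl behaves the same way with the cyclopropanecarbonyl group of compound 1 on the core.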